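The compounds below may be only part of what the source reports. "The series", "measured", "known", "first", "only" and "open" are said of these compounds alone.

For the measured compounds named here, compound 2 `CCCCCCCCCCCCCCCC(=O)NCCC(=O)Nc1cccc(S(=O)(=O)Nc2cccc(C)c2C)c1` gives 18% in an in vitro assay on Sf9 cells for inhibition of CAAX prenyl protease 2 (Homo sapiens), tested at 10 uM (a lower number here means less inhibition, a higher number more inhibition at the concentration tested (going by the name of the read-out)), the higher of the two numbers measured so far. Compound 1 `CCCCCCCCCCCCCCCC(=O)NCCC(=O)Nc1cccc(C(=O)Nc2cccc(C)c2C)c1` gives 11% in this assay. Going by the values given here, the one measured step, a number 7 percentage points higher from compound 1 to compound 2 (within the scatter), concerns the sulfonyl group and not the aryl on the sulfonamide nitrogen. Compound 3 `CCCCCCCCCCCCCCCC(=O)NCCC(=O)Nc1cccc(S(=O)(=O)Nc2cccc3ccccc23)c1` differs from compound 2 by naphthalen-1-yl in place of 2,3-dimethylphenyl on a sulfonamide nitrogen. Among the compounds with values here, no measured step touches this position, so nothing in the data points to a change in either direction. For compound 3 a step of no change at the digits printed from compound 2 to compound 3 (within the scatter) is expected, which lies within the scatter. Compound 3 is estimated at 18%, within 5% to 35%.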

Compound 3, a percentage reported as inhibition, at one concentration (the size of the read-out at that concentration, not a potency): < 5%
Compound 3: a limit, no number (the forecaster's own chance of this, stated with the estimate: 0%); middle value at least 13 percentage points from the limit.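

The aryl on the sulfonamide nitrogen matters in this assay: naphthalen-1-yl in place of 2,3-dimethylphenyl gives a number at least 13 percentage points lower from compound 2 to compound 3 (beyond the scatter). This is the only step shown beyond the scatter, whereas the change at the sulfonyl group stays within it. The reading for compound 3 is a limit, not a number: the limit of < 5% in this assay, at which 1 of the 3 values shown sits.

On these data alone, whether the drop follows from the second aromatic ring or from the loss of the two methyl groups stays open. Also open, as far as these compounds go, is how this assay responds to a plain phenyl, or to an aryl carrying a carboxylic acid or an amine, on this nitrogen.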